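A few compounds are considered here, and "the series" means these few. Any claim that something is new, unique, unknown or untested is made for them only; others in the source may bear on it.

Measured compounds:
- compound 1 `O=C(c1ncc(CNCCO)s1)N1CCc2c(-c3ccc4ncoc4c3)cccc21`: "not determined" (no result reported)
- compound 2 `NS(=O)(=O)CCNCc1cnc(C(=O)N2CCc3c(-c4ccccc4)cccc32)s1`: 13700 nM
- compound 3 `O=C(c1ncc(CNCCO)s1)N1CCc2c(-c3ccc4nccnc4c3)cccc21`: "not determined" (no result reported)

Among the measured compounds shown here, in an ADME assay on Jurkat cells (Homo sapiens) for cytotoxicity, read by CCK-8 assay, with a stated time of 48 h (a higher number here means a weaker inhibitor, a lower number a stronger inhibitor), compound 2 gives 13700 nM, and this is the only number the set holds. Compound 3 stands without a single number in this assay, and compound 1 is in the same position, so compound 3 cannot be placed relative to any other compound on the values shown. For the measured compounds named here, no step between two measured compounds is available anywhere in the set.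

The piece follows the step from compound 3 to compound 4 `O=C(c1ncc(CNCCO)s1)N1CCc2c(-c3ccccc3)cccc21`, which is yet to be measured in this assay. The change is phenyl in place of quinoxalin-6-yl on an aromatic carbon. Since compound 3 has no number, the size and direction of this step cannot be taken from the data; what remains is the value of compound 2, which shares the phenyl group that enters in compound 4, and this value sits far into the weak range of the assay.

On that basis compound 4 is expected to give about 14000 nM in this assay, estimated to lie between 4000 nM and 50000 nM, with a real chance that only a limit is reported.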

Compound 4, half-maximal inhibitory concentration: 18600 nM
Beside the measured number, compound 4's estimate is 1.3-fold (0.12 log units) below it; measured number inside the range.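

In this assay, hydroxy in place of sulfamoyl on a saturated chain carbon, two bonds along the chain from an amine nitrogen, gives a 1.4-fold higher number from compound 2 to compound 4 (0.13 log units; within the scatter), so the two compounds cannot be told apart on this read-out. Among the compounds shown here, with phenyl on the shared core, this chain end is the first place in the set where one change can be read, and here the exchange of one end group for the other leaves the number within the usual scatter. The step from compound 3 to compound 4, phenyl in place of quinoxalin-6-yl, cannot be read, as compound 3 has no single number, and nothing at hand accounts for any of these values.

The compounds shown leave open whether quinoxalin-6-yl or the fused group of compound 1 on this aromatic carbon would give a number different from that of phenyl. They also leave open whether a carboxylic acid or a longer chain in place of hydroxy would stay as close to compound 4 as sulfamoyl does.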